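A few compounds are considered here, and "the series" means these few. Any claim that something is new, unique, unknown or untested is made for them only; others in the source may bear on it.

In a functional assay on A549 cells (Homo sapiens) for antiproliferative activity, read by sulforhodamine B assay, with a stated time of 3 days (on this read-out lower numbers stand for stronger inhibition of growth and higher numbers for weaker inhibition of growth), compound 1 `O=C(Nc1ccccn1)c1cccc(Nc2ncc(F)c(Nc3ccc(F)cc3)n2)c1` gives 15300 nM and compound 2 `O=C(Nc1cccc(Nc2ncc(F)c(Nc3ccc(F)cc3)n2)c1)c1cnccn1` gives 10300 nM. These two values amount to a 1.5-fold lower number from compound 1 to compound 2 (0.17 log units; within the scatter). Compound 3 `CN(C)c1ccc(C(=O)Nc2cccc(Nc3ncc(F)c(Nc4ccc(F)cc4)n3)c2)cc1` has no number in this assay, since its entry of > 10000 nM is a limit.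

Compound 4 `CN(C)CC(=O)Nc1cccc(Nc2ncc(F)c(Nc3ccc(F)cc3)n2)c1` differs from compound 3 at a single place, where (dimethylamino)methyl stands in place of 4-(dimethylamino)phenyl on a carbonyl carbon: (dimethylamino)methyl in place of 4-(dimethylamino)phenyl on a carbonyl carbon. The ring on that carbonyl carbon is lost, and the dimethylamino group stays.

The closest measured change at this carbonyl carbon is a step that the limit leaves unreadable from compound 2 to compound 3, and it gives no size to carry over, as the limit of > 10000 nM in this assay, at which 1 of the 3 values shown sits, shows. For the measured compounds named here, the only readable step, a 1.5-fold lower number from compound 1 to compound 2 (0.17 log units; within the scatter), stays within the scatter, but it concerns a different exchange. Going by the values given here, no measured compound has a ringless group on this carbonyl carbon, so the data support no particular direction for the change. The expectation therefore rests on the neighbouring value of compound 2 at 10300 nM, with a wide margin. There is also a real chance that compound 4 gives another limit.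

The expected change is a number no higher from compound 3 to compound 4 (the limit leaves the size open). For compound 4 the estimated value is 10000 nM, with an expected range of 3500 nM to 30000 nM.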

Compound 4, concentration for 50% growth inhibition: 1180 nM
For compound 4 the middle estimate is 8.5-fold (0.93 log units) above the measured one; the measured number lies below the stated range.
By their numbers in this assay, from the lowest: compound 4; then compounds 2 and 1 (each within the scatter of the next).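

In this assay, the group on this carbonyl carbon now proves able to move the number beyond the scatter, with (dimethylamino)methyl in place of pyrazin-2-yl giving an 8.7-fold lower number from compound 2 to compound 4 (0.94 log units; beyond the scatter), and the exchange for (pyridin-2-yl)carbamoyl giving the largest step shown, a 13-fold lower number from compound 1 to compound 4 (1.11 log units; beyond the scatter). The dimethylamino group stands on both sides of the exchange for 4-(dimethylamino)phenyl, which gives an at least 8.4-fold lower number from compound 3 to compound 4 (0.92 log units; beyond the scatter), so that group alone does not set the result, and the six-membered aromatic ring of carbon only is what leaves along with the change in the link to it. Compound 3 stands only as a limit, so the size of that step stays open on one side: the limit of > 10000 nM in this assay, at which 1 of the 4 values shown sits.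

The compounds shown leave open whether the lower number belongs to the dimethylamino group on the short chain or to the chain itself, a question that a primary amine, a methoxy group or a longer chain at this carbonyl carbon would help to separate. Whether the same order holds in other cell lines is open as well.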